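Pyrrolidin-2-yl in place of the amino alcohol chain

This account rests on a few compounds, and the source may have more. Where it says the series, first, only, none or still open, it means among the compounds named here.

The three measured compounds share one core and differ only in the substituent on a triple-bonded carbon. In a functional assay on SW480 cells (Homo sapiens) for inhibition (a lower number here means a stronger inhibitor, a higher number a weaker inhibitor), compound 1 `COc1cc[nH]c1/C=C1\C(=O)Nc2ccc(F)c(C#C[C@H](N)CO)c21` gives 270 nM. Compound 2 `CN[C@@H](C#Cc1c(F)ccc2c1/C(=C/c1[nH]ccc1OC)C(=O)N2)CO` gives 80 nM, and compound 3 `CN[C@H](C#Cc1c(F)ccc2c1/C(=C/c1[nH]ccc1OC)C(=O)N2)CO` gives 100 nM. The step of a 3.4-fold lower number from compound 1 to compound 2 (0.53 log units; beyond the scatter) and the step of a 2.7-fold lower number from compound 1 to compound 3 (0.43 log units; beyond the scatter) are both modest and beyond the scatter, while the step of a 1.3-fold higher number from compound 2 to compound 3 (0.10 log units; within the scatter) lies within it, as is consistent with the fact that compounds 2 and 3 differ only in the configuration as drawn. Compound 3 therefore stands second highest of the three numbers, close to compound 2 and clearly below compound 1.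

Compound 4 `COc1cc[nH]c1/C=C1\C(=O)Nc2ccc(F)c(C#C[C@@H]3CCCN3)c21` is not yet measured. Relative to compound 3 it carries pyrrolidin-2-yl in place of 2-hydroxy-1-(methylamino)ethyl on a triple-bonded carbon. For the measured compounds named here, no measured step covers this change: two steps add a methyl to the amine nitrogen, the third alters only configuration. Together they show only that this substituent tolerates modest alteration without large swings. The account therefore expects a step of a 1.5-fold higher number from compound 3 to compound 4 (0.18 log units; within the scatter) that stays small. Compound 4 is estimated at 150 nM, between 50 nM and 500 nM.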

Compound 4, half-maximal inhibitory concentration: 40 nM
For compound 4 the middle estimate is 3.8-fold (0.57 log units) above the measured one; measured number outside the range, below it.
By their numbers in this assay, from the lowest: compounds 4, 2 and 3 (each within the scatter of the next, the first and the last beyond it); then compound 1.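

In this assay, the hydroxy group of the amino alcohol chain proves dispensable on this triple-bonded carbon: pyrrolidin-2-yl, a five-membered non-aromatic ring without that group, gives a 2.5-fold lower number from compound 3 to compound 4 (0.40 log units; beyond the scatter) and a 6.8-fold lower number from compound 1 to compound 4 (0.83 log units; beyond the scatter) as its two steps beyond the scatter. Against the other methylamino compound the reading is a 2.0-fold lower number from compound 2 to compound 4 (0.30 log units; within the scatter), so compound 4 cannot be told apart from compound 2. Nothing available accounts for these steps.

Open, as far as these compounds go, is whether the ring or the loss of the hydroxy group carries the step to compound 4, a question that an open-chain 1-(methylamino)ethyl group would address. Also open, from the compounds shown here alone, is how the opposite configuration of pyrrolidin-2-yl, or a piperidin-2-yl or azetidin-2-yl ring, would read at this position.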